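A few compounds are considered here, and "the series" means these few. Any claim that something is new, unique, unknown or untested is made for them only; others in the source may bear on it.

Working notes on the series.

Compound 2 `C[C@@H](Cc1ccc2ncnn2c1)CN1C[C@@H]2CCCC[C@@H]2[C@H](C(=O)N2CCN(c3ccc(F)c(F)c3)CC2)C1` is the weaker of the two measured compounds: in an assay on isolated protein for binding affinity to somatostatin receptor type 1 (Homo sapiens) (a lower number here means tighter binding, a higher number weaker binding), compound 2 gives 9120 nM, the highest number of the two, and compound 1 `Cc1cn2cc(C[C@H](C)CN3C[C@@H]4CCCC[C@@H]4[C@H](C(=O)N4CCN(c5ccc(F)c(F)c5)CC4)C3)ccc2n1` gives 39.8 nM in this assay. Among the compounds with values here, the only step that connects them, a 230-fold higher number from compound 1 to compound 2 (2.36 log units; beyond the scatter), attaches to the same saturated chain carbon that the change now under review touches, so that position is known to move this assay strongly.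

Compound 3 `CCNc1ccc(C[C@H](C)CN2C[C@@H]3CCCC[C@@H]3[C@H](C(=O)N3CCN(c4ccc(F)c(F)c4)CC3)C2)cn1` differs from compound 2 in exactly that spot: a group of 9 heavy atoms (7 carbon, 2 nitrogen; one six-membered aromatic ring with 1 hetero atom) in place of a group of 9 heavy atoms (6 carbon, 3 nitrogen; one five-membered aromatic ring with 3 hetero atoms, one six-membered aromatic ring with 1 hetero atom), on a saturated chain carbon, three bonds along the chain from an amine nitrogen in a ring. Within the data shown here, no measured step tells how the 6-(ethylamino)pyridin-3-yl group compares with either of the two groups already measured, so the direction can only be argued from the fact that compound 2 sits at the poor end of a wide range, leaving far more room downward than upward.

On that basis the step of a 23-fold lower number from compound 2 to compound 3 (1.36 log units; beyond the scatter) is expected to be a move to a lower number, though not necessarily back to the level of compound 1. For compound 3 the estimate in this assay is 400 nM, with a range from 40 nM to 4000 nM, the range kept wide because one step cannot fix the size.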

Compound 3, dissociation constant: 1910 nM
Compound 3: middle estimate off by 4.8-fold (0.68 log units), on the low side, within the range that was stated.
By their numbers in this assay, from the lowest: compound 1; then compound 3; then compound 2.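

In this assay the 6-(ethylamino)pyridin-3-yl group of compound 3 gives an intermediate result at this saturated chain carbon, with a 4.8-fold lower number from compound 2 to compound 3 (0.68 log units; beyond the scatter) and a 48-fold higher number from compound 1 to compound 3 (1.68 log units; beyond the scatter), so the position does not simply divide groups into one tight-binding and one weak-binding class. Ring count does not order the three compounds: compound 1 and compound 2 both carry a five-membered and a six-membered aromatic ring yet lie at opposite ends, while compound 3, with a single six-membered aromatic ring, falls between them, and compound 2 and compound 3 differ beyond the scatter despite the same count of heavy atoms in the group. No evidence on the cause of these differences is at hand.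

The compounds shown do not separate the contribution of the ethylamino chain from that of the pyridine ring; a plain pyridin-3-yl, 6-aminopyridin-3-yl or 6-(dimethylamino)pyridin-3-yl group at the same carbon would address this. Also open, from the compounds shown here alone, is where a group like that of compound 1 would fall without its methyl group.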